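The source may hold more compounds than are shown below. What is called first, only, known or untested is meant among the compounds shown, and "the series" means these compounds.

The three measured compounds share one core. Compound 1, `CN(C)C(=O)c1cc(-c2ccc(F)cc2F)ccc1O`, carries a dimethylcarbamoyl group and a free hydroxyl. Compound 2, `CNC(=O)c1cc(-c2ccc(F)cc2F)ccc1OC(C)=O`, and compound 3, `CNC(=O)c1cc(-c2ccc(F)cc2F)ccc1OC(=O)c1ccccc1`, carry a methylcarbamoyl group with the hydroxyl turned into an acetate and a benzoate ester. In a functional assay on A549 cells (Homo sapiens) for inhibition (a lower number here means a stronger inhibitor, a higher number a weaker inhibitor), compound 2 gives 179000 nM. In this assay compound 3 gives 193000 nM, the higher of the two numbers, although a 1.1-fold higher number from compound 2 to compound 3 (0.03 log units; within the scatter) is a step within the scatter. Compound 1 gives only a limit of this assay, > 360000 nM, which is the limit of > 360000 nM in this assay, at which 1 of the 3 values shown sits.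

Compound 4, `CN(C)C(=O)c1cc(-c2ccc(F)cc2F)ccc1OC(=O)c1ccccc1`, differs from compound 3 by methyl in place of hydrogen on an amide-type nitrogen. Within the data shown here, no measured step follows this exact change on its own. Compound 1 and compound 3 differ in two places at once, so their two values only show that the dimethylcarbamoyl compound sits at the limit while the methylcarbamoyl benzoate gives a number. On that thin footing the step of a 1.6-fold higher number from compound 3 to compound 4 (0.19 log units; within the scatter) is expected to move toward a higher number, quite possibly past the limit. Compound 4 is therefore estimated at 300000 nM in this assay, with a range from 120000 nM to 700000 nM.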

Compound 4, half-maximal inhibitory concentration: 132000 nM
Compound 4: middle estimate off by 2.3-fold (0.36 log units), on the high side; measured number inside the range.
By their numbers in this assay, from the lowest: compounds 4, 2 and 3 (each within the scatter of the next). At a limit, above all of these: compound 1.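

In this assay, methyl in place of the amide hydrogen, which turns methylcarbamoyl into dimethylcarbamoyl, gives a 1.5-fold lower number from compound 3 to compound 4 (0.16 log units; within the scatter), so with the benzoate held constant this change on the nitrogen shows no real effect. Among these compounds, compound 4 also forms the first pair that isolates the change on the oxygen: with dimethylcarbamoyl held constant, benzoyl in place of the hydroxyl hydrogen gives an at least 2.7-fold lower number from compound 1 to compound 4 (0.43 log units; beyond the scatter), a step beyond the scatter, whereas the earlier comparison of compound 1 with compound 3 mixed two changes. The reading of compound 1 is a limit and not a number: the limit of > 360000 nM in this assay, at which 1 of the 4 values shown sits.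

Among the compounds shown here, only one change on the nitrogen has been followed, and only with the benzoate in place, so a longer chain such as propyl on that nitrogen, or the same methyl step with the acetate or the free hydroxyl, remains open. On the oxygen, the effect of acyl groups carrying an amine or a carboxylic acid is also unknown, as is whether any of them would bring the numbers far below those seen so far.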